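This account rests on a few compounds, and the source may have more. Where it says the series, first, only, none or still open, it means among the compounds named here.

In a functional assay on Raji cells (Homo sapiens) for antiproliferative activity, read by MTT assay, with a stated time of 48 h (on this read-out higher numbers stand for weaker inhibition and lower numbers for stronger inhibition), compound 1 `CN(C)CCn1c(N)c(-c2nc3ccccc3[nH]2)c2nc(C#N)c(C#N)nc21` gives 8320 nM. Compound 2 `N#Cc1nc2c(-c3nc4ccccc4[nH]3)c(N)n(CCCO)c2nc1C#N` gives > 50000 nM, which is a limit of the assay and not a number. Compound 3 `N#Cc1nc2c(-c3nc4ccccc4[nH]3)c(N)n(CCCN3CCCCC3)c2nc1C#N` carries piperidin-1-yl in place of hydroxy on a saturated chain carbon, three bonds along the chain from an aromatic nitrogen, that is, 3-hydroxypropyl to 3-(piperidin-1-yl)propyl. Among the compounds with values here, the one measured step that bears on this is an at least 6.0-fold higher number from compound 1 to compound 2 (0.77 log units; beyond the scatter), with hydroxymethyl in place of dimethylamino, and it lies beyond the scatter. Read in reverse, it suggests a move to lower numbers in this assay. The expected step is an at least 5.5-fold lower number from compound 2 to compound 3 (0.74 log units; beyond the scatter). Compound 3 is estimated at 9000 nM, with an expected range of 2500 nM to 35000 nM.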

Compound 3, half-maximal inhibitory concentration: 3380 nM
Estimate against measurement, compound 3: 2.7-fold (0.43 log units) above; the range from low to high includes it.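

In this assay, piperidin-1-yl in place of hydroxy at the end of the chain is a large gain, with an at least 14-fold lower number from compound 2 to compound 3 (1.17 log units; beyond the scatter) as the step. Compound 2 stands at a limit of the assay, so this step is a bound and not an exact size: the limit of > 50000 nM in this assay, at which 1 of the 3 values shown sits. Against the dimethylamino chain of compound 1 the gain is smaller, at a 2.5-fold lower number from compound 1 to compound 3 (0.39 log units; beyond the scatter), and this step changes the amine and the chain together.

A 2-(piperidin-1-yl)ethyl chain would separate those two changes. Also open, as far as these compounds go, is how morpholin-4-yl, pyrrolidin-1-yl or a longer chain would read here.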